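From But-3-en-1-yl to 4-Methylbenzyl at the Limit

The source may hold more compounds than are shown below. What is called first, only, known or untested is meant among the compounds shown, and "the series" means these compounds.

In an ADME assay on RAW264.7 cells (Mus musculus) for cytotoxicity, read by MTT assay, with a stated time of 24 h, in the absence of a further agent (on this read-out lower numbers stand for stronger inhibition and higher numbers for weaker inhibition), compound 1 `COCCCOc1ccc(C(O)C2OC(=O)c3c(OC)cc(OC)cc32)cc1` gives > 40000 nM as a limit of the assay. Compound 2 `CCOCCOc1ccc(C(O)C2OC(=O)c3c(OC)cc(OC)cc32)cc1` gives > 40000 nM as a limit too. Compound 3 `C=CCCOc1ccc(C(O)C2OC(=O)c3c(OC)cc(OC)cc32)cc1` gives > 40000 nM as another limit. Compound 3 therefore stands at the limit of > 40000 nM in this assay, at which 3 of the 3 values shown sit, and has no exact number. Compound 4 `COc1cc(OC)c2c(c1)C(C(O)c1ccc(OCc3ccc(C)cc3)cc1)OC2=O` differs from it thus: 4-methylphenyl in place of allyl on a saturated chain carbon bound to an oxygen on an aromatic ring with 4-methylphenyl in place of allyl. The measured changes on this chain are a step that the two limits leave unreadable from compound 1 to compound 2 and a step that the two limits leave unreadable from compound 1 to compound 3 and a step that the two limits leave unreadable from compound 2 to compound 3 so none gives a size to carry over. The estimated change is a number no higher from compound 3 to compound 4 (the limit leaves the size open) and no shift beyond the scatter is expected. For compound 4 the expected value is 40000 nM with an estimated range from 15000 nM to 80000 nM in this assay again.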

Compound 4, half-maximal inhibitory concentration: > 40000 nM
Compound 4: a limit, no number; the forecaster's own chance of this, stated with the estimate: 75%; the middle value lies on the limit itself.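

In this assay compound 4 gives > 40000 nM as a limit, not a number. Among these compounds, no step among compound 1, compound 2, compound 3 and compound 4 can be read, because all four share one limit: the limit of > 40000 nM in this assay, at which 4 of the 4 values shown sit.

From the compounds shown here alone, how the side chains of these four compounds compare in cytotoxicity stays open.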